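Cytotoxicity of a Nitroimidazole Series on Vero Cells

The source may report more compounds than this note shows. Statements on the series, on what has been measured and on what is new or still open speak of the compounds shown alone.

The account concerns three compounds that share one core. Among the compounds with values here, compound 1, `C[C@]1(CN2CCc3oc(-c4ccc(F)cc4)nc3C2)Cn2cc([N+](=O)[O-])nc2O1`, is the only one with a reading. Compound 2, `C[C@]1(CN2CCc3nc(N4CCC(F)(F)CC4)ccc3C2)Cn2cc([N+](=O)[O-])nc2O1`, carries 4,4-difluoropiperidin-1-yl, and compound 3, `C[C@]1(CN2CCc3nc(-c4ccc(F)cc4F)ccc3C2)Cn2cc([N+](=O)[O-])nc2O1`, is the compound yet to be tested. In an ADME assay on Vero cells (Chlorocebus sabaeus) for cytotoxicity, read by MTT assay, with a stated time of 72 h (a lower number here means that less compound is tolerated, a higher number that more compound is tolerated), compound 1 gives > 32 ug/mL, which is a limit of the assay rather than a number. Compound 2 stands nowhere on the numbers shown, since in this assay compound 2 gives "not determined" (no result reported). The only anchor available is therefore (the limit of > 32 ug/mL in this assay, at which 1 of the 2 values shown sits). The change from compound 2 to compound 3 is 2,4-difluorophenyl in place of 4,4-difluoropiperidin-1-yl on an aromatic carbon. Within the data shown here, no measured pair frames this step, so in this assay no shift beyond the usual scatter is expected in either direction, and compound 3 is taken to behave like compound 1. Compound 3 is expected to give 32 ug/mL, in a range from 16 ug/mL to 64 ug/mL, most likely reported again only as a limit.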

Compound 3, half-maximal cytotoxic concentration: 12.5 ug/mL
Compound 3: the middle estimate sits 2.6-fold (0.41 log units) above what was measured; measured number outside the range, below it.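

Within the data shown here, with no number for compound 2 in this assay, the exchange leading to compound 3 gives no step that can be read, and compound 1 differs from compound 3 in more than one place. The compounds shown leave open whether 2,4-difluorophenyl and 4,4-difluoropiperidin-1-yl differ at all in this assay.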